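A few compounds are considered here, and "the series" means these few. Any claim that something is new, unique, unknown or untested is made for them only; others in the source may bear on it.

Measured so far:
compound 1, `COc1cc(-n2ncnc2-c2ccc(Cl)cc2)cc(OC)c1OC` — > 10000 nM
compound 2, `COc1cc(-n2ncnc2-c2ccc(OC(C)C)cc2)cc(OC)c1OC` — 650 nM

Compound 1 has the structure `COc1cc(-n2ncnc2-c2ccc(Cl)cc2)cc(OC)c1OC`. On these data alone, in a functional assay on Jurkat cells (Homo sapiens) for antiproliferative activity, read by MTT assay, with a stated time of 72 h (a higher number here means a weaker inhibitor, a lower number a stronger inhibitor), compound 1 gives only a limit, > 10000 nM, so its true number is unknown and sits at the limit of > 10000 nM in this assay, at which 1 of the 2 values shown sits. Among the compounds with values here, compound 2, `COc1cc(-n2ncnc2-c2ccc(OC(C)C)cc2)cc(OC)c1OC`, gives 650 nM in this assay, and the step of an at least 15-fold lower number from compound 1 to compound 2 (1.18 log units; beyond the scatter) marks the one measured change, which swaps the chloro group for isopropoxy.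

Compound 3 has the structure `COc1cc(-n2ncnc2-c2cccc(F)c2)cc(OC)c1OC` and differs from compound 1 by 3-fluorophenyl in place of 4-chlorophenyl on an aromatic carbon. Within the data shown here, no measured step covers a change from one halogen to another or a shift of the substituent around the ring, so the step of an at least 15-fold lower number from compound 1 to compound 2 (1.18 log units; beyond the scatter) bears on it only in showing that this position of the shared core can move this assay strongly. Because compound 1 stands only at a limit (the limit of > 10000 nM in this assay, at which 1 of the 2 values shown sits), the expected step of an at least 1.2-fold lower number from compound 1 to compound 3 (0.09 log units; that floor lies within the scatter) is uncertain and may again end at a limit. Compound 3 is therefore estimated at 8000 nM, within a range from 1500 nM to 30000 nM.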

Compound 3, half-maximal inhibitory concentration: > 10000 nM
Compound 3 was reported as a limit; the forecaster's own chance of this, stated with the estimate: 55%; middle value at least 1.2-fold (0.09 log units) away from the limit.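

Within the data shown here, compound 1 and compound 3 both stand only at a limit, so no step between them can be read: the limit of > 10000 nM in this assay, at which 2 of the 3 values shown sit.

The compounds shown leave open how 3-fluorophenyl and 4-chlorophenyl truly compare in this assay and whether either compound would give an exact number there.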